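A few compounds are considered here, and "the series" means these few. Any claim that something is new, unique, unknown or untested is made for them only; others in the source may bear on it.

Measured in a functional assay on TSGH 8302 cells (Homo sapiens) for cytotoxicity; on this read-out lower numbers stand for stronger inhibition and higher numbers for weaker inhibition:
- Compound 1 `Cc1c(S(=O)(=O)N/C(=N\O)Nc2ccc(Cl)cc2)sc2ccc(Cl)cc12`: 44 ug/mL
- Compound 2 `O=[N+]([O-])c1ccc(Oc2c(Cl)cc(S(=O)(=O)N/C(=N\O)Nc3ccc(Cl)cc3)cc2Cl)cc1`: 7 ug/mL

Compound 2 holds the lower of these two numbers, and its gap to compound 1 lies beyond the usual scatter. Compound 3 `O=[N+]([O-])c1ccc(Oc2c(Cl)cc(S(=O)(=O)N/C(=N\O)Nc3ccc(Cl)cc3)cc2Cl)c(Cl)c1` has not yet been measured. It differs from compound 2 in one place: chloro in place of hydrogen on an aromatic carbon. Put simply, the 4-nitrophenoxy group becomes 2-chloro-4-nitrophenoxy. Within the data shown here, the two measured compounds differ in more than one place, so no measured step shows what this change does. The expectation therefore rests on compound 2, at 7 ug/mL, as the only close reference. In this assay, no step beyond the scatter is expected, in either direction. The estimated change is a 1.2-fold lower number from compound 2 to compound 3 (0.07 log units; within the scatter). Compound 3 is expected at 6 ug/mL, within an estimated range of 2.5 ug/mL to 15 ug/mL.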

Compound 3, half-maximal inhibitory concentration: 7 ug/mL
Beside the measured number, compound 3's estimate is 1.2-fold (0.07 log units) below it; the range from low to high includes it.
By their numbers in this assay, from the lowest: compounds 2 and 3 (each within the scatter of the next); then compound 1.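

Within this assay the swap of hydrogen for chloro, which turns the 4-nitrophenoxy group into 2-chloro-4-nitrophenoxy, brings no change at the digits printed from compound 2 to compound 3 (within the scatter) and gives the first reading of a single change among these compounds. At this aromatic carbon, ortho to a large group and meta to a nitro group, the added chlorine leaves a number that cannot be told apart from that of the parent compound. No measurement here offers an explanation for this result.

Going by these compounds, it remains open whether a different group at this same carbon, such as an amine, a methoxy group or a carboxylic acid, would also leave the number in place. The compounds shown also leave open whether chloro would behave the same way on the other carbons of this ring.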